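A few compounds are considered here, and "the series" means these few. Any claim that something is new, unique, unknown or untested is made for them only; others in the source may bear on it.

Compound 1, `CCN(C)c1nc(Cc2c(F)cccc2F)cc(=O)[nH]1`: in an ADME assay on MT4 cells (Homo sapiens) for cytotoxicity, read by MTT assay, with a stated time of 4 days (on this read-out lower numbers stand for higher toxicity in this test and higher numbers for lower toxicity in this test), compound 1 gives > 89000 nM, which is a limit of the assay rather than a number.
Compound 2, `CCN(CC)c1nc(Cc2c(F)cccc2F)cc(=O)[nH]1`: in this assay compound 2 gives > 85000 nM, again a limit.
Compound 3, `CCN(C)c1nc(Cc2c(F)cccc2F)c(C)c(=O)[nH]1`: in this assay compound 3 gives > 85000 nM, also a limit.

All three measured values are therefore limits. Compound 3 stands at the limit of > 85000 nM in this assay, at which 2 of the 3 values shown sit, sharing that position with compound 2. Compound 1 sits at the limit of > 89000 nM in this assay, at which 1 of the 3 values shown sits. None of the three reached a readable toxic concentration.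

Compound 4, `Cc1c(Cc2c(F)cccc2F)nc(N2CCC(C)CC2)[nH]c1=O`, differs from compound 3 by 4-methylpiperidin-1-yl in place of ethyl(methyl)amino on an aromatic carbon. Two measured steps offer a comparison. The step that the two limits leave unreadable from compound 1 to compound 2 and the step that the two limits leave unreadable from compound 1 to compound 3 both run between limits, so neither can show whether a small structural change moves the read-out at all. The change to compound 4 is larger than either of those, yet nothing in the three measurements points to toxicity appearing.

The step from compound 3 to compound 4 is expected to be a number no higher from compound 3 to compound 4 (the limit leaves the size open), most likely again unreadable. Compound 4 is expected to give about 85000 nM in this assay, within a range from 40000 nM to 150000 nM, and most probably reported only as a limit.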

Compound 4, half-maximal cytotoxic concentration: > 75000 nM
Compound 4: a limit, no number (the forecaster's own chance of this, stated with the estimate: 85%); the middle value is on the limit's open side.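

In this assay, compound 3 and compound 4 both give only limits rather than numbers, so the step between them cannot be read. The compounds shown leave open at what concentration any of them would become toxic to these cells, and whether 4-methylpiperidin-1-yl in place of ethyl(methyl)amino changes that concentration at all.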